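Aryl exchange on the shared core: cytotoxicity notes

The source may hold more compounds than are shown below. What is called first, only, known or untested is meant among the compounds shown, and "the series" means these compounds.

Among the compounds with values here, in a functional assay on DU-145 cells (Homo sapiens) for cytotoxicity, read by sulforhodamine B assay, with a stated time of 48 h (on this read-out lower numbers stand for stronger inhibition and higher numbers for weaker inhibition), two compounds on the shared core have numbers so far: compound 1 (`COc1ccc(C2=NO[C@]3(C2)C(=O)O[C@@H]2[C@H]3CC[C@H](C)[C@]3(O)C=CC(=O)[C@@]23C)cc1`) at 20000 nM and compound 2 (`C[C@H]1CC[C@@H]2[C@@H](OC(=O)[C@]23CC(c2ccc(N(C)C)cc2)=NO3)[C@]2(C)C(=O)C=C[C@@]12O`) at 4500 nM. Within the data shown here, compound 2 holds the lower of the two numbers, and compound 1 is its only neighbour.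

Compound 3 (`C[C@H]1CC[C@@H]2[C@@H](OC(=O)[C@]23CC(c2ccccc2[N+](=O)[O-])=NO3)[C@]2(C)C(=O)C=C[C@@]12O`) is next. Relative to compound 2 it carries 2-nitrophenyl in place of 4-(dimethylamino)phenyl on a carbon with a double bond to nitrogen.

Among the measured compounds shown here, one measured step bears on this change: a 4.4-fold lower number from compound 1 to compound 2 (0.65 log units; beyond the scatter), with dimethylamino in place of methoxy on an aromatic carbon. For the measured compounds named here, that step is modest, and it is the only measured change on this aromatic ring. Going by the values given here, compound 3 gives up the dimethylamino group, yet no measured compound carries a nitro group, so the guidance is loose.

A move back toward the weaker end is expected, with an estimated 2.4-fold higher number from compound 2 to compound 3 (0.39 log units; beyond the scatter) in this assay. The estimate for compound 3 is 11000 nM, with an expected range from 3500 nM to 30000 nM.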

Compound 3, half-maximal inhibitory concentration: 34000 nM
Estimate against measurement, compound 3: 3.1-fold (0.49 log units) below, and the stated range ends below it.
By their numbers in this assay, from the lowest: compound 2; then compounds 1 and 3 (each within the scatter of the next).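

In this assay, the step to 2-nitrophenyl on the carbon with a double bond to nitrogen gives a 7.6-fold higher number from compound 2 to compound 3 (0.88 log units; beyond the scatter), a larger shift at this position than a 4.4-fold lower number from compound 1 to compound 2 (0.65 log units; beyond the scatter), and the number returns to the level of the methoxy-bearing compound. Compared directly, the 4-methoxyphenyl and 2-nitrophenyl compounds show a 1.7-fold higher number from compound 1 to compound 3 (0.23 log units; within the scatter), so these two aryl groups cannot be told apart here, and among the three compounds only the 4-(dimethylamino)phenyl group of compound 2 stands apart. No measurement at hand explains the difference between these aryl groups.

The step from compound 2 to compound 3 changes both the substituent and its place on the aromatic ring, so the contribution of each remains unresolved, and a 4-nitrophenyl group on the shared core would be needed to separate them. Also open, as far as these compounds go, is whether the lower number of compound 2 is specific to dimethylamino or extends to other nitrogen groups at the same place on the ring, such as a primary amine or a morpholine.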